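The compounds below may be only part of what the source reports. "The series", "measured", "known", "first", "only" and "open" are said of these compounds alone.

Among the measured compounds shown here, compound 3 `Oc1ccc(-c2cc(-c3ccc(Cl)cc3)nc(-c3ccccn3)c2)cc1` carries a pyridin-2-yl group on the shared core, and in a functional assay on DU-145 cells (Homo sapiens) for cytotoxicity, read by CCK-8 assay and cell counting, with a stated time of 2 days (on this read-out lower numbers stand for stronger inhibition and higher numbers for weaker inhibition), compound 3 gives 22500 nM, the highest of the three numbers measured so far. The two neighbours differ from it only in that group. Compound 1 `Oc1ccc(-c2cc(-c3ccc(Cl)cc3)nc(-c3cccs3)c2)cc1`, with thiophen-2-yl in that place, gives 7660 nM in this assay, and compound 2 `Oc1ccc(-c2cc(-c3ccc(Cl)cc3)nc(-c3ccsc3)c2)cc1`, with thiophen-3-yl, gives 6940 nM; these two values lie within the scatter of each other. The step of a 2.9-fold higher number from compound 1 to compound 3 (0.47 log units; beyond the scatter) and the step of a 3.2-fold higher number from compound 2 to compound 3 (0.51 log units; beyond the scatter) both show the pyridin-2-yl compound with a modestly higher number.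

Compound 4 `Oc1ccc(-c2cc(-c3ccc(Cl)cc3)nc(-c3ccco3)c2)cc1` is not yet measured. The change from compound 3 is furan-2-yl in place of pyridin-2-yl on an aromatic carbon. The two measured steps bear on it directly: each replaced a five-membered aromatic ring with one hetero atom by pyridin-2-yl and raised the number modestly, and compound 4 reverses that kind of exchange. A step down in this assay of about that size is therefore expected, bringing compound 4 back near the values of compound 1 and compound 2, so the step from compound 3 is estimated as a 2.8-fold lower number from compound 3 to compound 4 (0.45 log units; beyond the scatter). Compound 4 is thus expected to give 8000 nM, with a range of 3500 nM to 18000 nM.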

Compound 4, half-maximal inhibitory concentration: 7280 nM
Compound 4: the middle estimate sits 1.1-fold (0.04 log units) above what was measured, and the stated range covers the measured number.
By their numbers in this assay, from the lowest: compounds 2, 4 and 1 (each within the scatter of the next); then compound 3.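

Set against compound 3 in this assay, furan-2-yl in place of pyridin-2-yl gives a 3.1-fold lower number from compound 3 to compound 4 (0.49 log units; beyond the scatter) and so extends the earlier contrast to a third five-membered aromatic ring with one hetero atom. The comparisons with the thiophenes give a 1.0-fold higher number from compound 2 to compound 4 (0.02 log units; within the scatter) and a 1.1-fold lower number from compound 1 to compound 4 (0.02 log units; within the scatter) and both lie within the scatter, so at this place, next to the ring nitrogen, the assay does not separate furan-2-yl, thiophen-2-yl and thiophen-3-yl. The earlier compounds shown here could have pointed to something particular to the thiophenes, but compound 4 shows that the gap is not confined to them: among the four compounds, compound 3, with its six-membered aromatic ring, is the only one that stands apart.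

Nothing measured here explains why pyridin-2-yl differs from the three five-membered rings. Going by these compounds, it also remains open whether an unsubstituted phenyl ring, a saturated morpholine ring or an open-chain amine at this place would fall with the five-membered rings, with compound 3 or elsewhere.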